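A few compounds are considered here, and "the series" means these few. Any claim that something is new, unique, unknown or untested is made for them only; others in the source may bear on it.

Measured so far:
compound 1 `CNCc1cc(-c2cccnc2F)n(S(=O)(=O)c2ccccn2)c1` — 81%
compound 2 `CNCc1cn(S(=O)(=O)c2ccoc2)c(-c2cccnc2F)c1F` — 95%

In a functional assay on the whole organism (strain Jcl:Sprague-Dawley) for inhibition, with Rattus norvegicus as the target, with stated times of 3 min and 3 h, at a dose of 1 mg/kg by the intravenous route (a higher number here means more inhibition at the dose given (going by the name of the read-out), a lower number less inhibition), compound 2 stands highest of the two numbers; compound 1 sits lower by a gap beyond the usual scatter. Compound 3 `CNCc1cn(S(=O)(=O)c2ccccn2)c(-c2cccnc2F)c1F` is not yet measured. It differs from compound 2 by pyridin-2-yl in place of furan-3-yl on a sulfonyl sulfur. Within the data shown here, no step between measured compounds isolates this change, so its size is not known from the series; compound 1 also carries pyridin-2-yl on the sulfonyl sulfur, yet differs from compound 2 in further places. For compound 3 a small step is expected, likely within the scatter or slightly downward, as a number 7 percentage points lower from compound 2 to compound 3 (within the scatter). Compound 3 is thus estimated at 88%, within 72% to 98%.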

Compound 3, a percentage reported as inhibition, in the whole organism at one dose (the size of the read-out at that dose, not a potency): 95%
The estimate for compound 3 lay 7 percentage points below the measured number; low and high end bracket the measured number.
By their numbers in this assay, from the lowest: compound 1; then compounds 2 and 3 (each within the scatter of the next).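

In this assay, pyridin-2-yl in place of furan-3-yl on the sulfonyl sulfur gives no change at the digits printed from compound 2 to compound 3 (within the scatter), so the two rings cannot be told apart here at this dose. Fluoro in place of hydrogen on an aromatic carbon gives a number 14 percentage points higher from compound 1 to compound 3 (beyond the scatter), the first change in the series isolated at a single place. No measurement available here accounts for either step. As far as these compounds go, whether phenyl or methyl on the sulfonyl sulfur keeps this level remains open, as does the effect of chloro in place of the fluoro. With a single dose, any difference in potency between the two rings also remains unresolved.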